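This account rests on a few compounds, and the source may have more. Where it says the series, first, only, none or still open, it means among the compounds named here.

Working notes on the series. Compound 1 `COc1ccc(N(C)c2ccnc(Cl)n2)cc1` gives 917 nM in a functional assay on HeLa cells (Homo sapiens) for antiproliferative activity, read by MTT assay, with a stated time of 48 h; on this read-out lower numbers stand for stronger inhibition and higher numbers for weaker inhibition. For the measured compounds named here, compound 2 `COc1ccc(N(C)c2ccnc(Cl)n2)cc1F` gives 241 nM in this assay, and the single change between them, fluoro in place of hydrogen on an aromatic carbon, moves the number by a 3.8-fold lower number from compound 1 to compound 2 (0.58 log units; beyond the scatter). Going by the values given here, compound 2 thus holds the lowest of the two numbers so far; its nearest neighbour is compound 1, whose number is higher by the same step.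

Compound 3 `COc1ccc(N(C)c2ccnc(Cl)n2)cc1Cl` differs from compound 2 in one place: chloro in place of fluoro on an aromatic carbon, on an aromatic carbon of a six-membered aromatic ring of carbon only, ortho to a methoxy group. Among the compounds with values here, no measured step exchanges one halogen for another, so the only step bearing on this is the hydrogen-to-fluoro step of a 3.8-fold lower number from compound 1 to compound 2 (0.58 log units; beyond the scatter), which says merely that this position tolerates a substituent. A step no larger than the scatter, in either direction, is expected in this assay. Compound 3 is therefore estimated at 220 nM, with a range from 80 nM to 650 nM, which means an expected step of a 1.1-fold lower number from compound 2 to compound 3 (0.04 log units; within the scatter).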

Compound 3, half-maximal inhibitory concentration: 517 nM
Compound 3: the middle estimate sits 2.4-fold (0.37 log units) below what was measured; the measured number falls inside the stated range.
By their numbers in this assay, from the lowest: compound 2; then compounds 3 and 1 (each within the scatter of the next).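

The exchange of one halogen for another on this aromatic carbon, ortho to a methoxy group, is not neutral in this assay: the change of fluoro to chloro gives a 2.1-fold higher number from compound 2 to compound 3 (0.33 log units; beyond the scatter), so the substituent's identity matters here and not merely its presence. Set against hydrogen, chloro gives a 1.8-fold lower number from compound 1 to compound 3 (0.25 log units; within the scatter), so compound 3 cannot be separated from compound 1, and of the two halogens only fluoro has a step from hydrogen beyond the scatter, which leaves compound 2 with the lowest number of the three. No measurement on hand accounts for this difference between fluoro and chloro.

Still open, on these data alone, is where a bromo, methyl, hydroxyl, nitrile or amine group on this same carbon would fall relative to compound 2 and compound 3, so two halogens and hydrogen cannot yet be read as a trend. Also open, as far as these compounds go, is whether the preference for fluoro over chloro would hold if the methoxy group or the chloro on the shared core were replaced by another group, such as an ethoxy group or an amine.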